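A few compounds are considered here, and "the series" means these few. Any claim that something is new, unique, unknown or untested is made for them only; others in the source may bear on it.

Measured compounds:
compound 1 `COc1cc(-c2ccnc3cc(-c4ccccc4)nn23)cc(OC)c1OC`, in a functional assay on HCT-116 cells (Homo sapiens) for inhibition, read by CCK-8 assay, with a stated time of 48 h (a higher number here means a weaker inhibitor, a lower number a stronger inhibitor), compound 1 gives 3880 nM
compound 2 `COc1cc(-c2ccnc3cc(-c4cn(C)c5ccccc45)nn23)cc(OC)c1OC`, in this assay compound 2 gives 762 nM

Compound 2 stands lowest of the two numbers; its nearest neighbour is compound 1, reached by a 5.1-fold lower number from compound 1 to compound 2 (0.71 log units; beyond the scatter). Compound 3 `COc1ccc(-c2cc3nccc(-c4cc(OC)c(OC)c(OC)c4)n3n2)cc1` differs from compound 2 by 4-methoxyphenyl in place of 1-methyl-1H-indol-3-yl on an aromatic carbon. For the measured compounds named here, the only step that bears on this is a 5.1-fold lower number from compound 1 to compound 2 (0.71 log units; beyond the scatter), where phenyl gave way to 1-methyl-1H-indol-3-yl. Since 4-methoxyphenyl is a single six-membered carbon ring like phenyl, most of that gain is expected to be given back, so the number for compound 3 is expected to rise by a 3.3-fold higher number from compound 2 to compound 3 (0.52 log units; beyond the scatter). Compound 3 is therefore estimated at 2500 nM, within 1000 nM to 6000 nM.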

Compound 3, half-maximal inhibitory concentration: 404 nM
The estimate for compound 3 lay 6.2-fold (0.79 log units) above the measured number, outside the stated range (below it).
By their numbers in this assay, from the lowest: compounds 3 and 2 (each within the scatter of the next); then compound 1.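

In this assay, the step of a 1.9-fold lower number from compound 2 to compound 3 (0.28 log units; within the scatter) lies within the scatter, so at this aromatic carbon 4-methoxyphenyl and 1-methyl-1H-indol-3-yl cannot be told apart, and a single six-membered ring serves as well as the two-ring group. The step of a 9.6-fold lower number from compound 1 to compound 3 (0.98 log units; beyond the scatter) lies beyond the scatter, so adding methoxy to phenyl is enough to improve on compound 1. Nothing available explains either step.

The compounds shown leave open whether this gain is specific to methoxy or would also come with a hydroxyl, a fluorine or an amine in its place. As far as these compounds go, whether a longer chain such as ethoxy would hold the number also remains open.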